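Sulfonamide aryl variation in a shared core series

The compounds below may be only part of what the source reports. "The series", "measured", "known", "first", "only" and "open" are said of these compounds alone.

Measured so far in a functional assay on SMMC-7721 cells (Homo sapiens) for antiproliferative activity, read by MTT assay, with a stated time of 72 h; a higher number here means a weaker inhibitor, a lower number a stronger inhibitor:
compound 1 `CN(c1ccc2[nH]c(-c3n[nH]c4ccccc34)cc2n1)S(=O)(=O)c1ccccc1` gives 12000 nM
compound 2 `CN(c1ccc2[nH]c(-c3n[nH]c4ccccc34)cc2n1)S(=O)(=O)c1cccc([N+](=O)[O-])c1` gives 5070 nM

Compound 2 holds the lowest of the two numbers in this assay, its nearest neighbour being compound 1; the change from compound 1 to compound 2, a nitro in place of hydrogen on an aromatic carbon, gave a 2.4-fold lower number from compound 1 to compound 2 (0.37 log units; beyond the scatter).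

Compound 3 `CN(c1ccc2[nH]c(-c3n[nH]c4ccccc34)cc2n1)S(=O)(=O)c1ccc(OC(F)(F)F)cc1` is not yet measured. It differs from compound 2 by 4-(trifluoromethoxy)phenyl in place of 3-nitrophenyl on a sulfonyl sulfur. For the measured compounds named here, no measured step covers this exchange directly. Going by the values given here, the only step available, from compound 1 to compound 2, shows that substitution on this phenyl ring can shift the number by a modest amount, but it changes neither the group nor the position in the same way. The expectation is therefore a step of a 1.4-fold higher number from compound 2 to compound 3 (0.14 log units; within the scatter) from compound 2 to compound 3, with wide uncertainty in either direction. Compound 3 is estimated at 7000 nM, within a range of 2500 nM to 20000 nM.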

Compound 3, half-maximal inhibitory concentration: 7160 nM
Compound 3: the middle estimate sits 1.0-fold (0.01 log units) below what was measured, within the range that was stated.
By their numbers in this assay, from the lowest: compounds 2, 3 and 1 (each within the scatter of the next, the first and the last beyond it).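

In this assay, 4-(trifluoromethoxy)phenyl in place of 3-nitrophenyl on the sulfonyl sulfur gives a 1.4-fold higher number from compound 2 to compound 3 (0.15 log units; within the scatter) and so does not separate these two substituted rings, although both the group and its ring position change. Measured against the plain phenyl, trifluoromethoxy gives a 1.7-fold lower number from compound 1 to compound 3 (0.22 log units; within the scatter) while the nitro step gives a 2.4-fold lower number from compound 1 to compound 2 (0.37 log units; beyond the scatter) so, of the two substituents shown, only nitro gives a step beyond the scatter. No evidence on the origin of these steps is available for this result.

Among the compounds shown, each substituent appears at one ring position only, so the effect of the group remains unseparated from that of its position. Also open, from the compounds shown here alone, is how an amine or a carboxylic acid on this phenyl ring would compare with compound 1 in this assay.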